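Moving the Fluorine to Another Place on the Core

A few compounds are considered here, and "the series" means these few. Any claim that something is new, unique, unknown or untested is made for them only; others in the source may bear on it.

Compound 1 `C#Cc1cc(-c2nc3ccccc3s2)ccc1N` gives 15 nM in a functional assay on MDA-MB-468 cells (Homo sapiens) for inhibition, with a stated time of 72 h; on this read-out higher numbers stand for weaker inhibition of growth and lower numbers for stronger inhibition of growth.
Compound 2 `C#Cc1cc(-c2nc3c(F)cccc3s2)ccc1N` gives 30 nM in this assay.
Compound 3 `C[Si](C)(C)C#Cc1cc(-c2nc3ccccc3s2)ccc1N` gives 560 nM in this assay.

Compound 1 has the lowest of the three numbers. Its nearest neighbour is compound 2, reached through a 2.0-fold higher number from compound 1 to compound 2 (0.30 log units; within the scatter); its furthest is compound 3, reached through a 37-fold higher number from compound 1 to compound 3 (1.57 log units; beyond the scatter), a large loss that comes from capping the triple-bonded carbon with a group of 4 heavy atoms.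

Compound 4 `C#Cc1cc(-c2nc3ccc(F)cc3s2)ccc1N` differs from compound 1 by fluoro in place of hydrogen on an aromatic carbon, sitting on an aromatic carbon of a six-membered aromatic ring of carbon only, part of a fused system of two rings. Among the compounds with values here, the only measured step that bears on this change is the one from compound 1 to compound 2, where a fluoro also replaced a hydrogen on that ring system and gave a 2.0-fold higher number from compound 1 to compound 2 (0.30 log units; within the scatter), a change within the scatter. The terminal alkyne, whose capping cost so much in compound 3, is untouched here.

For compound 4, therefore, no step beyond the scatter is expected in this assay, the estimated change being a 1.5-fold higher number from compound 1 to compound 4 (0.17 log units; within the scatter). Compound 4 is estimated at 22 nM, with a likely range from 8 nM to 60 nM.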

Compound 4, concentration for 50% growth inhibition: 23 nM
The estimate for compound 4 lay 1.0-fold (0.02 log units) below the measured number; measured number inside the range.
By their numbers in this assay, from the lowest: compounds 1, 4 and 2 (each within the scatter of the next); then compound 3.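

In this assay the fluoro at this place, meta to a fused ring and para to a fused ring, gives a 1.5-fold higher number from compound 1 to compound 4 (0.19 log units; within the scatter). Until now, only one fluoro position on the shared core could be read, so a step within the scatter might have been peculiar to that carbon; a second position now reads the same way, with compounds 4 and 2 also within the scatter of each other. No measurement shown here explains why this replacement leaves the number so little changed.

Fluoro is a single small atom, so it remains open whether a chlorine, a methoxy group or an amine at this carbon would also stay within the scatter of compound 1. From the compounds shown here alone, the effect of a fluoro on the other carbons of this ring also remains open.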